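The source may hold more compounds than are shown below. What is called first, only, known or untested is meant among the compounds shown, and "the series" means these compounds.

In an ADME assay on microsomes from liver (Homo sapiens) for metabolic stability, read by LC-MS, with a stated time of 40 min, tested at 0.5 uM (a lower number here means slower removal, a higher number faster removal of the compound), compound 1 (`CC(C)(CO)S(=O)(=O)c1cccc(NC(=O)c2cccnc2N2CCC3(CC2)CC3)c1`) gives 154 mL.min-1.g-1. Compound 2 (`CC(C)(C)NS(=O)(=O)c1cccc(NC(=O)c2ccc(NS(=O)(=O)C3(C)CC3)cc2N2CCC3(CC2)CC3)c1`) gives 90 mL.min-1.g-1, which lies within the scatter of compound 1. Compound 3 (`CC(C)(C)NS(=O)(=O)c1cccc(NC(=O)c2ncc(NC(C)(C)CO)nc2N2CCC3(CC2)CC3)c1`) gives 74 mL.min-1.g-1, a lower number than compound 1 and just beyond the scatter. Compound 2 and compound 3 each differ from compound 1 in more than one place, so neither isolates a single structural change.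

Compound 4 (`O=C(Nc1cccc(S(=O)(=O)N2CCCC2)c1)c1cccnc1N1CCC2(CC1)CC2`) keeps the core of compound 1 but carries pyrrolidin-1-yl in place of 1-(hydroxymethyl)-1-methylethyl on a sulfonyl sulfur. Among the compounds with values here, no measured pair shows this swap on its own, which leaves the forecast poorly anchored. The expectation therefore starts from compound 1 at 154 mL.min-1.g-1 and allows for only a small rise in this assay. The expected step is a 1.2-fold higher number from compound 1 to compound 4 (0.07 log units; within the scatter), an estimate that stays within the scatter. For compound 4, the estimated value is 180 mL.min-1.g-1, with an expected range from 80 mL.min-1.g-1 to 380 mL.min-1.g-1.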

Compound 4, intrinsic clearance in microsomes: > 399 mL.min-1.g-1
Compound 4 was reported as a limit; the forecaster's own chance of this, stated with the estimate: 5%; middle value at least 2.2-fold (0.34 log units) away from the limit.
By their numbers in this assay, from the lowest: compounds 3, 2 and 1 (each within the scatter of the next, the first and the last beyond it). At a limit, above all of these: compound 4.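

Compound 1 and compound 4 differ in one place, and this pair shows that the group on the sulfonyl sulfur matters: pyrrolidin-1-yl in place of 1-(hydroxymethyl)-1-methylethyl gives an at least 2.5-fold higher number from compound 1 to compound 4 (0.41 log units; beyond the scatter). For compound 4 the reading in this assay is a limit and not a number: the limit of > 399 mL.min-1.g-1 in this assay, at which 1 of the 4 values shown sits. Both groups have 5 heavy atoms, so the step comes without a change in that count, while the swap brings in a five-membered ring and a nitrogen and removes the oxygen, with its hydrogen-bond donor and acceptor.

This single pair cannot tell which of those differences counts. Also open, on these data alone, is where a morpholin-4-yl ring or an open-chain diethylamino group on the same sulfonyl sulfur would fall, and whether either would give a lower number than pyrrolidin-1-yl.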